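The source may hold more compounds than are shown below. What is called first, only, known or untested is meant among the compounds shown, and "the series" means these compounds.

Measured compounds:
compound 1 `COc1ccc(CCCCCCCCOc2ccc(CSc3cccc(C(=O)O)c3)nc2/C=C/C(=O)O)cc1` gives 550 nM
compound 2 `COc1ccc(CCCCCCCCOc2ccc(C[S+]([O-])c3cccc(C(=O)O)c3)nc2/C=C/C(=O)O)cc1` gives 3900 nM
compound 3 `COc1ccc(CCCCCCCCOc2ccc(CSCc3cccc(C(=O)O)c3)nc2/C=C/C(=O)O)cc1` gives 131 nM

Compound 3 holds the lowest number of the three in a functional assay on the whole organism with Homo sapiens as the target, read by calcium flux; on this read-out lower numbers stand for stronger inhibition and higher numbers for weaker inhibition; compound 1 is its nearest neighbour, separated by a 4.2-fold lower number from compound 1 to compound 3 (0.62 log units; beyond the scatter), and compound 2 the furthest, separated by a 30-fold lower number from compound 2 to compound 3 (1.47 log units; beyond the scatter). Compound 4 `COc1ccc(CCCCCCCCOc2ccc(C[S+]([O-])Cc3cccc(C(=O)O)c3)nc2/C=C/C(=O)O)cc1` differs from compound 3 by a group of 12 heavy atoms (8 carbon, 3 oxygen, 1 sulfur; one six-membered aromatic ring of carbon only) in place of a group of 11 heavy atoms (8 carbon, 2 oxygen, 1 sulfur; one six-membered aromatic ring of carbon only), on a saturated chain carbon bound to an aromatic carbon. Within the data shown here, the one measured step that bears on this is a 7.1-fold higher number from compound 1 to compound 2 (0.85 log units; beyond the scatter), where the sulfur of compound 1 carried the same added oxygen and the shared core, the chain and the carboxylic acids were otherwise unchanged. That step was modest and went upward, beyond the scatter. Among the measured compounds shown here, since the only precedent, a 7.1-fold higher number from compound 1 to compound 2 (0.85 log units; beyond the scatter), ran upward, compound 4 is expected to sit higher than compound 3 by a step of about a 6.9-fold higher number from compound 3 to compound 4 (0.84 log units; beyond the scatter) in this assay. The estimate for compound 4 is therefore 900 nM, with a likely range from 300 nM to 3000 nM.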

Compound 4, half-maximal inhibitory concentration: 3300 nM
The estimate for compound 4 lay 3.7-fold (0.56 log units) below the measured number; measured number above the stated range.
By their numbers in this assay, from the lowest: compound 3; then compound 1; then compounds 4 and 2 (each within the scatter of the next).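

In this assay, the added oxygen on the sulfur weighs more on the (3-carboxybenzyl)sulfanyl group than the earlier pair suggested, with a large 25-fold higher number from compound 3 to compound 4 (1.40 log units; beyond the scatter) against the modest 7.1-fold higher number from compound 1 to compound 2 (0.85 log units; beyond the scatter). With that oxygen in place, 3-carboxybenzyl and 3-carboxyphenyl on the sulfur cannot be told apart, at a 1.2-fold lower number from compound 2 to compound 4 (0.07 log units; within the scatter), so the gain from 3-carboxybenzyl seen without the oxygen does not carry over: the same change on two cores in this assay, a 4.2-fold lower number (0.62 log units; beyond the scatter) from compound 1 to compound 3 and a 1.2-fold lower number (0.07 log units; within the scatter) from compound 2 to compound 4, 3.6-fold (0.55 log units) apart, beyond the scatter of two such steps With both changes made, the number still rises, by a 6.0-fold higher number from compound 1 to compound 4 (0.78 log units; beyond the scatter), so the gain from 3-carboxybenzyl does not offset the added oxygen.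

The compounds shown leave open how a sulfone, with two oxygens on the sulfur, would read here. They also leave open whether an ether oxygen or a methylene group in place of the sulfur would match compound 3.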